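Swapping methyl for phenyl on the ring nitrogen

This account rests on a few compounds, and the source may have more. Where it says the series, first, only, none or still open, it means among the compounds named here.

Measured compounds:
compound 1, `COC(=O)c1c(O)c2ccccc2n(-c2ccccc2)c1=O`, 100%
compound 2, `Cn1c(=O)c(C(=O)NCCCCCCN)c(O)c2ccccc21`, 92.1%

Both compounds were tested in an assay on isolated protein for inhibition of seed linoleate 13S-lipoxygenase-1 (Glycine max), tested at 0.1 mM; a lower number here means less inhibition, a higher number more inhibition at the concentration tested (going by the name of the read-out). Compound 1 gives 100%, while compound 2 gives 92.1%; these two numbers lie within the usual scatter of each other, so neither number can be called higher or lower than the other. Compound 3, `NCCCCCCNC(=O)c1c(O)c2ccccc2n(-c2ccccc2)c1=O`, has not yet been tested. It differs from compound 2 in one place: phenyl in place of methyl on an aromatic nitrogen. Compound 3 thus carries the same phenyl on its ring nitrogen as compound 1 and the same amide chain as compound 2. Among the compounds with values here, with no measured step on record for this change, and with compound 1 and compound 2 sitting so close together, the expected step of a number 3.9 percentage points higher from compound 2 to compound 3 (within the scatter) is one that stays within the scatter, if anything leaning upward. Compound 3 is therefore estimated at 96%, with a range from 85% to 100%.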

Compound 3, a percentage reported as inhibition, at one concentration (the size of the read-out at that concentration, not a potency): 17.6%
Compound 3: middle estimate off by 78.4 percentage points, on the high side; the measured number lies below the stated range.
By their numbers in this assay, from the lowest: compound 3; then compounds 2 and 1 (each within the scatter of the next).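

In this assay, the ring nitrogen proves to be a sensitive place once the amide chain is present: phenyl in place of methyl gives a number 74.5 percentage points lower from compound 2 to compound 3 (beyond the scatter), and with phenyl kept, (6-aminohexyl)amino in place of methoxy on the carbonyl carbon gives a number 82.4 percentage points lower from compound 1 to compound 3 (beyond the scatter) as well. Phenyl and the chain each occur in a compound with a high number, yet together they give a low one, so across these three compounds the outcome of either change depends on the other group. No measurement available here explains this drop.

Still open, going by these compounds, is whether ethyl or benzyl on the ring nitrogen would keep the number high alongside the aminohexyl chain. A shorter aminobutyl chain, or a carboxylic acid in place of the end amine, might also behave differently alongside phenyl.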